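From Nitro to Trifluoromethyl: An Expected Loss of Inhibition

A few compounds are considered here, and "the series" means these few. Any claim that something is new, unique, unknown or untested is made for them only; others in the source may bear on it.

Compound 1 `Cc1ccc(/C=N/c2ccccc2)c(C)c1`: 88400 nM
Compound 2 `O=[N+]([O-])c1ccc(/C=N/c2ccccc2)cc1`: 1600 nM

In a functional assay on A549 cells (Homo sapiens) for antiproliferative activity, read by MTT assay, with a stated time of 48 h (on this read-out higher numbers stand for weaker inhibition and lower numbers for stronger inhibition), compound 2 gives 1600 nM, the lower of the two numbers and so the stronger inhibition. Its distance from compound 1, at 88400 nM, lies well beyond the usual scatter.

Compound 3 `FC(F)(F)c1ccc(/C=N/c2ccccc2)cc1` is built from compound 2 by one change, trifluoromethyl in place of nitro on an aromatic carbon.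

Among the compounds with values here, no measured pair here differs in only one place, so the data offer no direct guide to this swap, and any forecast is uncertain. A moderate move toward a higher number in this assay, meaning weaker inhibition, is expected, and it could stay close to the scatter. The estimated change is a 2.5-fold higher number from compound 2 to compound 3 (0.40 log units; beyond the scatter). For compound 3 the estimated value is 4000 nM, with an expected range from 900 nM to 20000 nM.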

Compound 3, half-maximal inhibitory concentration: 138000 nM
Compound 3: middle estimate off by 35-fold (1.54 log units), on the low side, outside the stated range (above it).
By their numbers in this assay, from the lowest: compound 2; then compounds 1 and 3 (each within the scatter of the next).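

In this assay trifluoromethyl in place of nitro gives an 86-fold higher number from compound 2 to compound 3 (1.94 log units; beyond the scatter) and so much weaker inhibition. Within the data shown here, this is the only pair here that differs in one place, and it shows that the group on this aromatic carbon, para to a group of 8 heavy atoms, matters greatly: with the rest of the compound unchanged, nitro goes with far stronger inhibition than trifluoromethyl. Nothing available here explains why these two groups are so far apart. As far as these compounds go, whether an amine, a carboxylic acid or a methoxy group on the same carbon would come closer to compound 2 or to compound 3 remains open. Also open, from the compounds shown here alone, is whether this swap would bring a step of similar size on another core, since this single pair cannot show that.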